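The source may report more compounds than this note shows. Statements on the series, on what has been measured and on what is new or still open speak of the compounds shown alone.

Measured compounds:
- compound 1 `CC/C=C\C(=O)Nc1cc(Nc2ncc(C#N)c(-c3cn(C)c4ccc(F)cc34)n2)c(OC)cc1N(C)CCN(C)C`, in a functional assay on NCI-H1975 cells (Homo sapiens) for antiproliferative activity, read by MTT assay, with a stated time of 72 h (on this read-out higher numbers stand for weaker inhibition and lower numbers for stronger inhibition), compound 1 gives 10200 nM
- compound 2 `COc1cc(N(C)CCN(C)C)c(NC(=O)/C=C\C(C)C)cc1Nc1ncc(C#N)c(-c2cn(C)c3ccc(F)cc23)n1`, in this assay compound 2 gives 1130 nM
- compound 3 `CC/C=C\C(=O)Nc1cc(Nc2nc(C)cc(-c3cn(C)c4ccc(F)cc34)n2)c(OC)cc1N(C)CCN(C)C`, in this assay compound 3 gives 10400 nM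

Compound 1 and compound 2 share one core and differ in one place only: methyl in place of hydrogen on a saturated chain carbon bound to a double-bonded chain carbon and a saturated chain carbon. On this change the number moved by a 9.0-fold lower number from compound 1 to compound 2 (0.96 log units; beyond the scatter), so the added methyl made the compound a markedly stronger inhibitor of cell growth. Compound 3 carries a different core from compound 1; the difference between the two cores is not broken down here. Its value and that of compound 1 lie within the scatter of each other, so nothing can be said about any order between them.

Compound 4 `COc1cc(N(C)CCN(C)C)c(NC(=O)/C=C\C(C)C)cc1Nc1nc(C)cc(-c2cn(C)c3ccc(F)cc23)n1` is not yet measured. It stands to compound 3 as compound 2 stands to compound 1: methyl in place of hydrogen on a saturated chain carbon bound to a double-bonded chain carbon and a saturated chain carbon. The place of the change is described in the same words for both pairs, so it is the same kind of change on a different core. Because the step of a 9.0-fold lower number from compound 1 to compound 2 (0.96 log units; beyond the scatter) was clearly beyond the scatter, and because compound 3 gives 10400 nM, a step of similar direction and size is expected from compound 3 to compound 4, tempered only by the fact that this change has been seen on one core alone. The expected step for compound 4 is a 6.9-fold lower number from compound 3 to compound 4 (0.84 log units; beyond the scatter). For compound 4 the estimated value in this assay is 1500 nM, with an expected range from 500 nM to 4500 nM.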

Compound 4, half-maximal inhibitory concentration: 8520 nM
Compound 4: middle estimate off by 5.7-fold (0.75 log units), on the low side, outside the stated range (above it).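

In this assay, putting methyl in place of hydrogen on a saturated chain carbon bound to a double-bonded chain carbon and a saturated chain carbon, which turns but-1-en-1-yl into 3-methylbut-1-en-1-yl, gives a 1.2-fold lower number from compound 3 to compound 4 (0.09 log units; within the scatter), so on this core the change has no effect that can be told apart from ordinary repeat-to-repeat variation. The clear gain in strength seen on the other core did not carry over, and the two results are genuinely different: the same change on two cores in this assay, a 9.0-fold lower number (0.96 log units; beyond the scatter) from compound 1 to compound 2 and a 1.2-fold lower number (0.09 log units; within the scatter) from compound 3 to compound 4, 7.4-fold (0.87 log units) apart, beyond the scatter of two such steps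

For the compounds shown here, this shows that, in this series, the result of this change on one core cannot simply be assumed for another, but it rests on only two pairs of compounds and does not show which feature of the two cores separates them, or why.

The compounds shown leave open whether a longer chain, such as propyl in place of the added methyl, or an amine on the same saturated chain carbon would also behave differently on the two cores. They also leave open which of the two results, if either, a third core would follow.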